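Dropping the Chloro: From Compound 3 to Compound 4

A few compounds are considered here, and "the series" means these few. Any claim that something is new, unique, unknown or untested is made for them only; others in the source may bear on it.

Three compounds share one core and differ only in where a chloro sits. In a functional assay on HEK293 cells for agonist activity at Free fatty acid receptor 1 (Homo sapiens), read by fluorescence and calcium flux, with a stated time of 10 min (a higher number here means a larger maximal response, a lower number a smaller maximal response), compound 3 `CC#C[C@@H](CC(=O)O)c1ccc(OC[C@H]2COc3cccc(Cl)c3O2)cc1` gives 95%, the highest of the three numbers. Compound 1 `CC#C[C@@H](CC(=O)O)c1ccc(OC[C@H]2COc3ccc(Cl)cc3O2)cc1` gives 86%, a value within the scatter of compound 3, so the two cannot be ranked. Compound 2 `CC#C[C@@H](CC(=O)O)c1ccc(OC[C@H]2COc3cc(Cl)ccc3O2)cc1` gives 80%, a gap from compound 3 that lies beyond the scatter. Compound 4 `CC#C[C@@H](CC(=O)O)c1ccc(OC[C@H]2COc3ccccc3O2)cc1` has not been measured; it differs from compound 3 in one place: hydrogen in place of chloro on an aromatic carbon. Going by the values given here, no step between measured compounds is available, so the effect of losing the chloro is unknown. Since all three measured values lie close together, the expected step of a number 10 percentage points lower from compound 3 to compound 4 (within the scatter) is small, downward or none beyond the scatter. Compound 4 is estimated at 85%, ranging from 70% to 98%.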

Compound 4, largest response reached (Emax), in percent of the reference or control that the assay uses: 70%
For compound 4 the middle estimate is 15 percentage points above the measured one; measured number inside the range.
By their numbers in this assay, from the lowest: compounds 4, 2, 1 and 3 (each within the scatter of the next, the first and the last beyond it).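

In this assay, losing the chloro gives a number 25 percentage points lower from compound 3 to compound 4 (beyond the scatter) and a number 16 percentage points lower from compound 1 to compound 4 (beyond the scatter), so in those two placings a chloro gives a larger maximal response than hydrogen. The third placing gives a number 10 percentage points lower from compound 2 to compound 4 (within the scatter), so there chloro and hydrogen cannot be told apart. Nothing at hand explains these steps. From the compounds shown here alone, whether a fluoro or a methoxy group on the same aromatic carbons would match the chloro remains open, as does the effect of a second chloro on the same ring.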